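The source may hold more compounds than are shown below. What is called first, only, known or untested is meant among the compounds shown, and "the series" means these compounds.

Compound 1, `COc1ccc(NC(=O)Nc2cc(C)nc3ccccc23)cc1`, gives 787 10^-6 cm/s in an ADME assay for permeability, using PAMPA, at pH 7.4; a higher number here means that the compound crosses the layer faster, a lower number that the compound crosses the layer more slowly.
Compound 2, `Cc1ccc(NC(=O)Nc2cc(C)nc3ccccc23)cc1`, gives 669 10^-6 cm/s in this assay.
Compound 3, `CC(=O)c1ccc(NC(=O)Nc2cc(C)nc3ccccc23)cc1`, gives 473 10^-6 cm/s in this assay.

The three compounds share one core and differ only in the group on the aromatic ring. Compound 3 stands at 473 10^-6 cm/s, and the steps leading to it, a 1.7-fold lower number from compound 1 to compound 3 (0.22 log units; within the scatter) and a 1.4-fold lower number from compound 2 to compound 3 (0.15 log units; within the scatter), both lie within the scatter, as does a 1.2-fold lower number from compound 1 to compound 2 (0.07 log units; within the scatter); the three numbers therefore stand together rather than apart.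

Compound 4, `COC(=O)c1ccc(NC(=O)Nc2cc(C)nc3ccccc23)cc1`, differs from compound 3 in one place: methoxy in place of methyl on a carbonyl carbon. Cut one bond further out, the same change reads acetyl to methoxycarbonyl. Among the measured compounds shown here, no measured step makes exactly this change, and the steps that bear on it are those that swap the group on that ring, a 1.4-fold lower number from compound 2 to compound 3 (0.15 log units; within the scatter) and a 1.7-fold lower number from compound 1 to compound 3 (0.22 log units; within the scatter), none of which moved beyond the scatter. Compound 4 is therefore expected to stay close to compound 3, with an estimated step of a 1.1-fold lower number from compound 3 to compound 4 (0.02 log units; within the scatter). In this assay compound 4 is estimated at 450 10^-6 cm/s, in a range from 250 10^-6 cm/s to 800 10^-6 cm/s.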

Compound 4, apparent permeability: 448 10^-6 cm/s
Estimate against measurement, compound 4: 1.0-fold (0.00 log units) above; the range from low to high includes it.
By their numbers in this assay, from the lowest: compounds 4, 3, 2 and 1 (each within the scatter of the next).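

Among the compounds shown here, the ester is the first change made on the carbonyl carbon rather than directly on the aromatic carbon, and swapping methyl for methoxy there, which brings in one hydrogen-bond acceptor, stays within the scatter (a 1.1-fold lower number from compound 3 to compound 4 (0.02 log units; within the scatter)). The methoxycarbonyl group also stays within the scatter of the two simpler groups on that aromatic carbon, both against methyl (a 1.5-fold lower number from compound 2 to compound 4 (0.17 log units; within the scatter)) and against methoxy (a 1.8-fold lower number from compound 1 to compound 4 (0.24 log units; within the scatter)). Across these four compounds, then, methoxy, methyl, acetyl and methoxycarbonyl all give numbers that stand together in this assay, and the new step widens the span of groups without separating any of them.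

From the compounds shown here alone, whether a carboxylic acid, an amine or a longer chain in the same place would stay with these four remains open. Nothing available speaks to what lies behind these numbers.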